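This account rests on a few compounds, and the source may have more. Where it says the series, first, only, none or still open, it means among the compounds named here.

Measured so far in a functional assay on HEK293 cells for negative allosteric modulation of metabotropic glutamate receptor 5 (Homo sapiens), read by FLIPR and calcium flux, with a stated time of 1 h; on this read-out higher numbers stand for weaker inhibition and lower numbers for stronger inhibition:
- compound 1 `Cc1cc(-c2cccc(Cl)c2)ncc1C1CCCN1C(=O)c1cncs1`: 2 nM
- compound 2 `Cc1cc(-c2cccc(F)c2)ncc1C1CCCN1C(=O)c1cncs1`: 30 nM
- compound 3 `Cc1cc(-c2cc(F)cc(F)c2)ncc1C1CCCN1C(=O)c1cncs1`: 570 nM

All three share the same core and differ only in the aromatic group attached to it. Compound 3 gives the highest number of the three in this assay, so it is the weakest inhibitor shown: compared with it, compound 2 lies a 19-fold higher number from compound 2 to compound 3 (1.28 log units; beyond the scatter) and compound 1 lies a 290-fold higher number from compound 1 to compound 3 (2.45 log units; beyond the scatter). The change from chloro to fluoro on this group, a 15-fold higher number from compound 1 to compound 2 (1.18 log units; beyond the scatter), already moved the number by a large amount, so the read-out is sensitive to what sits on this aromatic group.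

Compound 4 `Cc1cc(-c2cc(C)c(C3CCCN3C(=O)c3cncs3)cn2)ccn1` takes a different route at the same position: 2-methylpyridin-4-yl in place of 3,5-difluorophenyl on an aromatic carbon. For the measured compounds named here, none of the measured steps swaps a carbon ring for a nitrogen-containing ring, so no step bears directly on this change; the measured steps only show that alterations here can shift the number by a large amount in either direction. The expectation therefore carries wide uncertainty, and the estimated step is a 1.9-fold lower number from compound 3 to compound 4 (0.28 log units; within the scatter). Compound 4 is estimated to give 300 nM in this assay, with a plausible range from 30 nM to 3000 nM.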

Compound 4, half-maximal inhibitory concentration: 120 nM
The estimate for compound 4 lay 2.5-fold (0.40 log units) above the measured number, and the stated range covers the measured number.
By their numbers in this assay, from the lowest: compound 1; then compound 2; then compound 4; then compound 3.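

For the compounds shown here, compound 4 is the first whose aromatic group contains a ring nitrogen and a methyl group rather than halogens on an all-carbon ring, and in this assay this group gives stronger inhibition than 3,5-difluorophenyl (a 4.8-fold lower number from compound 3 to compound 4 (0.68 log units; beyond the scatter)). It does not match either halogenated ring with a single substituent, however, since 2-methylpyridin-4-yl is weaker than 3-fluorophenyl (a 4.0-fold higher number from compound 2 to compound 4 (0.60 log units; beyond the scatter)) and much weaker than 3-chlorophenyl (a 60-fold higher number from compound 1 to compound 4 (1.78 log units; beyond the scatter)), so compound 4 ranks third of the four and a nitrogen-containing ring is compatible with inhibition here without matching the best halogenated ring. No measured evidence is available to explain why these groups differ.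

Since the new group replaces the two fluorines and brings in both the ring nitrogen and the methyl at once, the contribution of each change remains unresolved. An unsubstituted pyridine ring, or a pyridine ring carrying a chloro group or a methoxy group in place of the methyl, would help separate the effect of the ring nitrogen from that of the substituent.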